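From a methoxyphenyl arm to a chlorophenyl one

The source may report more compounds than this note shows. Statements on the series, on what has been measured and on what is new or still open speak of the compounds shown alone.

Within the data shown here, in a physicochemical assay for lipophilicity, measured as octanol-water partition (on this read-out higher numbers stand for higher lipophilicity and lower numbers for lower lipophilicity), compound 2 `COc1ccc(/C=C2\S/C(=N\c3ccccc3)N(CC(C)C)C2=O)cc1` gives 5.22, the higher of the two numbers measured so far, while compound 1 `COc1ccc(/C=C2\S/C(=N\c3ccccc3)N(CC(C)C)C2=O)cc1OC` gives 5.06. The two stand close: a number 0.16 log units higher from compound 1 to compound 2 (within the scatter), so neither can be called the more lipophilic. Compound 3 `CC(C)CN1C(=O)/C(=C/c2cccc(Cl)c2)S/C1=N\c1ccccc1` is not yet measured. It differs from compound 2 by 3-chlorophenyl in place of 4-methoxyphenyl on a double-bonded chain carbon bound to a double-bonded ring carbon. Among the measured compounds shown here, no measured step covers this exchange; the one step in hand removes a methoxy group and stays within the scatter, so it offers only a weak guide. The exchange of a methoxy-bearing ring for a chlorine-bearing one is nonetheless expected to raise the number in this assay, with an estimated step of a number 0.68 log units higher from compound 2 to compound 3 (beyond the scatter), clearly beyond the scatter. Compound 3 is therefore expected to give about 5.9 in this assay, with a range from 5.5 to 6.3.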

Compound 3, partition coefficient: 5.98
Beside the measured number, compound 3's estimate is 0.08 log units below it; measured number inside the range.
By their numbers in this assay, from the lowest: compounds 1 and 2 (each within the scatter of the next); then compound 3.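

In this assay the exchange of 4-methoxyphenyl for 3-chlorophenyl on a double-bonded chain carbon bound to a double-bonded ring carbon gives a number 0.76 log units higher from compound 2 to compound 3 (beyond the scatter) and so lies beyond the scatter, unlike a number 0.16 log units higher from compound 1 to compound 2 (within the scatter) where hydrogen took the place of methoxy on an aromatic carbon. This position therefore admits a change that the read-out can resolve, which compounds 1 and 2 alone could not show. No measurement at hand accounts for the size of this step.

The exchange alters both the group on the ring and where it sits, so the compounds shown leave open how much of the rise goes with chlorine itself and how much with its place. Also open, as far as these compounds go, is how the number would answer a 4-chlorophenyl group here, or an amine or a carboxylic acid on this ring.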